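Benzyl to allyl swap on two related cores

A few compounds are considered here, and "the series" means these few. Any claim that something is new, unique, unknown or untested is made for them only; others in the source may bear on it.

Compound 1 `O=C(CN1C(=O)S/C(=C\c2ccc(F)cc2)C1=O)NOCc1ccccc1` gives, in an ADME assay on RAW264.7 cells (Mus musculus) for cytotoxicity, read by neutral red uptake, with a stated time of 24 h (on this read-out lower numbers stand for higher toxicity in this test and higher numbers for lower toxicity in this test), only a limit of > 128000 nM. Compound 2 `C=CCONC(=O)CN1C(=O)S/C(=C\c2ccc(F)cc2)C1=O` likewise returns a limit of > 128000 nM in this assay. The change between them is vinyl in place of phenyl on a saturated chain carbon bound to an oxygen and the step that the two limits leave unreadable from compound 1 to compound 2; the limit of > 128000 nM in this assay, at which 2 of the 3 values shown sit, leaves its size unreadable. Within the data shown here, compound 3 `CCCC/C=C1\SC(=O)N(C(C)C(=O)NOCc2ccccc2)C1=O` gives 43900 nM in this assay, the only number in the set; the difference between the core of compound 3 and the core of compound 1 is not broken down here. Compound 4 `C=CCONC(=O)C(C)N1C(=O)S/C(=C\CCCC)C1=O` carries the same change, (vinyl in place of phenyl on a saturated chain carbon bound to an oxygen). The step of a 1.1-fold higher number from compound 3 to compound 4 (0.06 log units; within the scatter) is expected to be small, since the measured pair gives no readable size and no evidence points either way. Compound 4 is estimated at 50000 nM, with a range of 15000 nM to 150000 nM.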

Compound 4, half-maximal cytotoxic concentration: > 128000 nM
Compound 4: a limit, no number; the forecaster's own chance of this, stated with the estimate: 30%; at least 2.5-fold (0.40 log units) between middle value and limit.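

In this assay, the change from benzyloxy to allyloxy on the core of compound 3 gives an at least 2.9-fold higher number from compound 3 to compound 4 (0.46 log units; beyond the scatter), which points to lower toxicity in this test for the allyloxy member of this pair. The same change on the core of compound 1 cannot be read, and the pair on the core of compound 3 gives only a lower bound on the step. Whether the change has the same size on both cores therefore stays unresolved: the limit of > 128000 nM in this assay, at which 3 of the 4 values shown sit.

Open, as far as these compounds go, is how an amine or a carboxylic acid in place of the phenyl, on a saturated chain carbon bound to an oxygen, would read in this assay. From the compounds shown here alone, a longer chain in that place is equally open.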